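From nitro to methoxy: what compound 4 should show

The source may hold more compounds than are shown below. What is called first, only, known or untested is meant among the compounds shown, and "the series" means these compounds.

Measured so far in an ADME assay on cells (spleen, Mus musculus, strain C57BL/6) for inhibition, read by flow cytometry and propidium iodide staining, with a stated time of 24 h, at 37 degrees C; a lower number here means that less compound is needed, a higher number that more compound is needed for the effect

compound 1 `CC(C)(O)c1cn(CC(=O)NCc2ccccc2)nn1` gives 1600 uM
compound 2 `Nc1cccc(-c2cn(CC(=O)NCc3ccccc3)nn2)c1` gives 800 uM
compound 3 `O=C(Cn1cc(-c2ccc([N+](=O)[O-])cc2)nn1)NCc1ccccc1` gives 800 uM

In this assay compound 3 gives 800 uM and so stands level with compound 2 at 800 uM while compound 1 at 1600 uM lies within the scatter of both. The next compound, compound 4 `COc1ccc(-c2cn(CC(=O)NCc3ccccc3)nn2)cc1` carries methoxy in place of nitro on an aromatic carbon, para to a large group (methoxy in place of nitro on an aromatic carbon). Within the data shown here, no measured step exchanges either of these two groups. Among the measured compounds shown here, the only step between measured compounds that differ in one place is a 2.0-fold lower number from compound 1 to compound 2 (0.30 log units; within the scatter) and it concerns another exchange, so it bears on this change only indirectly. For the measured compounds named here, it does show that the numbers so far sit close together, and no step beyond the scatter is expected here. The estimate amounts to no change at the digits printed from compound 3 to compound 4 (within the scatter) as the expected outcome. For compound 4 the estimated value is 800 uM with an expected range from 400 uM to 1600 uM in repeated measurements.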

Compound 4, concentration for half-maximal effect: "non-toxic" (no number reported)
The entry for compound 4 holds no number; no gap can be computed for the estimate.
By their numbers in this assay, from the lowest: compounds 2, 3 and 1 (each within the scatter of the next).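

In this assay, among these compounds, compound 4 is recorded only as "non-toxic", with no number, so no step from compound 3 to compound 4 can be read. No measurement shown bears on this result. The compounds shown leave open how methoxy and nitro compare numerically in this assay.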